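Amide substituent swap on the piperazine-linked quinolone series

A few compounds are considered here, and "the series" means these few. Any claim that something is new, unique, unknown or untested is made for them only; others in the source may bear on it.

Compound 2 `COc1cc(NC(=O)CN2CCN(c3cc4c(cc3F)c(=O)c(C(=O)O)cn4C3CC3)CC2)cc(OC)c1OC` carries a 3,4,5-trimethoxyphenyl on the amide-type nitrogen. In an ADME assay on WI-38 cells (Homo sapiens) for antiproliferative activity, read by BrdU incorporation, with a stated time of 24 h (on this read-out higher numbers stand for weaker inhibition and lower numbers for stronger inhibition), compound 2 gives > 100000 nM, which is a limit of the assay and not a number. Compound 1 `COc1ccccc1NC(=O)CN1CCN(c2cc3c(cc2F)c(=O)c(C(=O)O)cn3C2CC2)CC1` carries a 2-methoxyphenyl at the same place. In this assay compound 1 gives > 100000 nM, again a limit. The step that the two limits leave unreadable from compound 1 to compound 2 therefore cannot be read, since the limit of > 100000 nM in this assay, at which 2 of the 2 values shown sit, shows both values sitting at the limit. Compound 3 `O=C(CN1CCN(c2cc3c(cc2F)c(=O)c(C(=O)O)cn3C2CC2)CC1)NC1CCCCC1` differs from compound 2 in that (cyclohexyl in place of 3,4,5-trimethoxyphenyl on an amide-type nitrogen). Going by the values given here, no measured step with a readable size bears on this change; the one measured step left both of its ends at the limit, so no direction beyond the scatter can be drawn from it. The step from compound 2 to compound 3 in this assay is expected to end at the limit as well, making a number no higher from compound 2 to compound 3 (the limit leaves the size open) only nominal. Compound 3 is therefore estimated to give 100000 nM in this assay, with a range from 30000 nM to 300000 nM, most probably reported as a limit once more.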

Compound 3, half-maximal inhibitory concentration: > 100000 nM
Compound 3: a limit, no number; the forecaster's own chance of this, stated with the estimate: 80%; the middle value sits exactly at the limit.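

No new step can be read among compound 1, compound 2 and compound 3, since all three values are limits and not numbers: the limit of > 100000 nM in this assay, at which 3 of the 3 values shown sit.

The compounds shown leave open how the cyclohexyl, 2-methoxyphenyl and 3,4,5-trimethoxyphenyl groups on the amide-type nitrogen rank in this assay, and whether any substituent at that place on the shared core gives a readable number.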